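Side-chain change on the shared core: compound 3 to compound 4

The compounds below may be only part of what the source reports. "The series", "measured", "known", "first", "only" and "open" are said of these compounds alone.

In an assay on isolated protein (strain Sprague-Dawley) for inhibition of Amine oxidase [flavin-containing] B (Rattus norvegicus), read by spectrophotometry, with a stated time of 5 min (on this read-out higher numbers stand for weaker inhibition and lower numbers for stronger inhibition), compound 3 `CCOC(=O)COc1cc(=O)oc2cc(OCc3cccc(Cl)c3)ccc12` gives 1820 nM, the second highest of the three numbers measured: compound 1 `O=c1cc(O)c2ccc(OCc3cccc(F)c3)cc2o1` gives 2090 nM, within the scatter of compound 3, while compound 2 `O=c1cc(O)c2ccc(OCc3cccc(Br)c3)cc2o1` gives 490 nM, beyond it. Among the measured compounds shown here, the one measured step, a 4.3-fold lower number from compound 1 to compound 2 (0.63 log units; beyond the scatter), concerns a halogen swap on an aromatic carbon and does not touch the part of the molecule varied here. Compound 4 `CCOC(=O)c1cc(=O)oc2cc(OCc3cccc(Cl)c3)ccc12` differs from compound 3 by ethoxycarbonyl in place of (ethoxycarbonyl)methoxy on an aromatic carbon. For the measured compounds named here, no measured step bears on that change, so no step beyond the scatter is assumed in either direction. Compound 4 is therefore expected to stay close to its parent, at 1800 nM (range 600 nM to 5500 nM). The estimate means a step of a 1.0-fold lower number from compound 3 to compound 4 (0.00 log units; within the scatter), expected to fall within the usual scatter.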

Compound 4, half-maximal inhibitory concentration: 417 nM
The estimate for compound 4 lay 4.3-fold (0.64 log units) above the measured number, outside the stated range (below it).
By their numbers in this assay, from the lowest: compounds 4 and 2 (each within the scatter of the next); then compounds 3 and 1 (each within the scatter of the next).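

In this assay, the aromatic carbon opposite the ring oxygen proves sensitive to its substituent: ethoxycarbonyl in place of (ethoxycarbonyl)methoxy gives a 4.4-fold lower number from compound 3 to compound 4 (0.64 log units; beyond the scatter), beyond the scatter. Among the compounds shown here, the earlier compounds varied only the halogen, so this is the first sign that this position matters. Nothing at hand explains the step.

From the compounds shown here alone, whether the gain follows from the shorter group or from the ester attached directly to the ring remains open. A carboxylic acid or an amide at this position would test how much depends on the ethyl ester.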